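Chloro in Place of Ethyl on the Fused Core

The source may report more compounds than this note shows. Statements on the series, on what has been measured and on what is new or still open speak of the compounds shown alone.

Compound 2 `CCc1nn(C)c2c1C(c1ccccc1)=NCC(=O)N2` stands lowest of the two numbers measured in a functional assay on the whole organism with Rattus norvegicus as the target (a higher number here means that more compound is needed for the effect, a lower number that less compound is needed), giving 8 mg/kg. Its nearest neighbour, compound 1 `Cn1ncc2c1NC(=O)CN=C2c1ccccc1`, gives 250 mg/kg in this assay. Among the compounds with values here, the one step joining them, a 31-fold lower number from compound 1 to compound 2 (1.49 log units; beyond the scatter), is large and beyond the scatter, and it shows how much the group on that aromatic carbon weighs in this pair. Compound 3 `Cn1nc(Cl)c2c1NC(=O)CN=C2c1ccccc1` is the next member: chloro in place of ethyl on an aromatic carbon. Within the data shown here, only the step from compound 1 to compound 2 bears on this change, and it was large; it tells that a group on that aromatic carbon lowers the number, but not whether chloro behaves as ethyl did. On that basis compound 3 is expected to fall between the two measured numbers, a step of a 2.5-fold higher number from compound 2 to compound 3 (0.40 log units; beyond the scatter). The estimate for compound 3 in this assay is 20 mg/kg, within 6 mg/kg to 70 mg/kg.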

Compound 3, minimum effective dose: 63 mg/kg
Beside the measured number, compound 3's estimate is 3.2-fold (0.50 log units) below it; low and high end bracket the measured number.
By their numbers in this assay, from the lowest: compound 2; then compound 3; then compound 1.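

In this assay, chloro on this aromatic carbon also gives a lower number than hydrogen (a 4.0-fold lower number from compound 1 to compound 3 (0.60 log units; beyond the scatter)), so the gain from a group here is not confined to ethyl. The two groups are not interchangeable, however: the number rises when chloro replaces ethyl (a 7.9-fold higher number from compound 2 to compound 3 (0.90 log units; beyond the scatter)), and among these three compounds the order runs from ethyl through chloro to hydrogen. Nothing available accounts for the gap between ethyl and chloro.

With only hydrogen, chloro and ethyl shown on this carbon, it remains open whether a longer chain such as propyl would lower the number further or whether ethyl is already near the best. On these data alone, how bromo, a methoxy group or an amine would fare at this position also remains open.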